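Trimethoxyphenyl to methylphenyl swap on a limit-bound compound

A few compounds are considered here, and "the series" means these few. Any claim that something is new, unique, unknown or untested is made for them only; others in the source may bear on it.

In a functional assay on ECa-109 cells (Homo sapiens) for inhibition, read by MTT assay, with a stated time of 72 h (a higher number here means a weaker inhibitor, a lower number a stronger inhibitor), compound 1 `COc1cc(-c2nc(SCc3cn(CC(=O)NC(=O)Nc4ccccn4)nn3)nc(Nc3ccc(C)cc3)c2C#N)cc(OC)c1OC` gives 21300 nM. Compound 2 `COc1cc(-c2nc(SCc3cn(CC(=O)NC(=O)Nc4ccccn4)nn3)nc(Nc3cccc(C(F)(F)F)c3)c2C#N)cc(OC)c1OC` reaches only a limit of this assay, > 64000 nM. Compound 3 `COc1cc(-c2nc(SCc3cn(CC(=O)NC(=O)Nc4ccccn4)nn3)nc(Nc3cccc(Cl)c3)c2C#N)cc(OC)c1OC` likewise stops at a limit, > 64000 nM. Compound 2 therefore stands at the limit of > 64000 nM in this assay, at which 2 of the 3 values shown sit, at the weak end of what the numbers show, with no finite value of its own. The measured steps all change the group on a nitrogen on an aromatic ring: an at least 3.0-fold higher number from compound 1 to compound 2 (0.47 log units; beyond the scatter) and an at least 3.0-fold higher number from compound 1 to compound 3 (0.47 log units; beyond the scatter), while a step that the two limits leave unreadable from compound 2 to compound 3. Compound 4 `Cc1ccc(-c2nc(SCc3cn(CC(=O)NC(=O)Nc4ccccn4)nn3)nc(Nc3cccc(C(F)(F)F)c3)c2C#N)cc1` differs from compound 2 by 4-methylphenyl in place of 3,4,5-trimethoxyphenyl on an aromatic carbon. For the measured compounds named here, no measured pair alters that part of the shared core, so none of the three compounds bears directly on this step; the measured steps only fix the starting point at a limit. Compound 4 is expected to stay near that limit, so the step that the limit leaves unreadable from compound 2 to compound 4 is estimated as not readable beyond the scatter. The estimate for compound 4 in this assay is 70000 nM, between 20000 nM and 250000 nM, most likely reported again as a limit.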

Compound 4, half-maximal inhibitory concentration: 32300 nM
For compound 4 the middle estimate is 2.2-fold (0.34 log units) above the measured one; the measured number falls inside the stated range.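

For the compounds shown here, this position, on an aromatic carbon ortho to a cyano group, is changed here for the first time, and with the (3-(trifluoromethyl)phenyl)amino group held constant, 4-methylphenyl in place of 3,4,5-trimethoxyphenyl gives a finite reading in this assay: compound 4 gives 32300 nM. From the compounds shown here alone, the change is an at least 1.9-fold lower number from compound 2 to compound 4 (0.29 log units; that floor lies within the scatter), so this pair cannot establish a real gain, and its true size remains unknown. The reading also rests on a limit for compound 2: the limit of > 64000 nM in this assay, at which 2 of the 4 values shown sit.

Within this one pair, 3,4,5-trimethoxyphenyl is not required for a finite reading. Going by these compounds, whether the same swap behaves alike with the 4-methylphenyl group of compound 1 on the nitrogen remains open, as does what an unsubstituted phenyl or a 4-aminophenyl group would give at this position.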